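Swapping the Aryl Ether Ring at a Potency Limit

A few compounds are considered here, and "the series" means these few. Any claim that something is new, unique, unknown or untested is made for them only; others in the source may bear on it.

Two compounds share one core and differ only in the ring joined through an oxygen to an aromatic ring. Compound 1 has the structure `C[C@@H](Cn1c(=O)[nH]/c(=N\c2ccc(Oc3ccccn3)cc2)n(Cc2ccc(Cl)cc2)c1=O)C(=O)O`. In an assay on isolated protein for antagonist activity at P2X purinoceptor 2 (Homo sapiens) (on this read-out lower numbers stand for stronger inhibition and higher numbers for weaker inhibition), compound 1 gives > 30000 nM, which is a limit of the assay rather than a number. Compound 2 has the structure `C[C@@H](Cn1c(=O)[nH]/c(=N\c2ccc(Oc3ccnc(F)c3)cc2)n(Cc2ccc(Cl)cc2)c1=O)C(=O)O`. In this assay compound 2 gives > 30000 nM, again a limit and not a number. The step that the two limits leave unreadable from compound 1 to compound 2 cannot be read because both ends sit at the same limit (the limit of > 30000 nM in this assay, at which 2 of the 2 values shown sit). Compound 3 has the structure `C[C@@H](Cn1c(=O)[nH]/c(=N\c2ccc(Oc3ccsn3)cc2)n(Cc2ccc(Cl)cc2)c1=O)C(=O)O` and has not yet been measured. It differs from compound 2 in one place: 1,2-thiazol-3-yl in place of 2-fluoropyridin-4-yl on an oxygen on an aromatic ring. Going by the values given here, no measured step gives a readable size for a change at this position, and the two values seen so far both stop at the limit, so nothing suggests that compound 3 will move away from it. The expected step of a number no higher from compound 2 to compound 3 (the limit leaves the size open) is therefore none beyond the scatter. Compound 3 is expected to give about 30000 nM, within a range from 10000 nM to 100000 nM.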

Compound 3, half-maximal inhibitory concentration: > 30000 nM
Compound 3: a limit, no number (the forecaster's own chance of this, stated with the estimate: 80%); the middle value lies on the limit itself.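

The steps among compound 1, compound 2 and compound 3 cannot be read, because all three stop at a limit rather than a number: the limit of > 30000 nM in this assay, at which 3 of the 3 values shown sit.

On these data alone, how strongly any of the three inhibits in this assay stays open, as does whether any other ring on this oxygen would give a readable number.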